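A few compounds are considered here, and "the series" means these few. Any claim that something is new, unique, unknown or untested is made for them only; others in the source may bear on it.

Compound 1 `O=C(Nc1nnc(-c2ccc(O)c(O)c2)s1)c1ccc(Cl)cc1`: 47300 nM
Compound 2 `O=C(COc1ccccc1)Nc1nnc(-c2cccc(O)c2O)s1`: 117000 nM
Compound 3 `O=C(COc1ccccc1)Nc1nnc(-c2ccc(O)c(O)c2)s1`: 51300 nM

All three numbers come from a functional assay on HeLa cells (Homo sapiens) for cytotoxicity, read by MTT assay, with a stated time of 72 h; a higher number here means a weaker inhibitor, a lower number a stronger inhibitor. Compound 2 stands highest of the three: compound 3 lies nearest, with a 2.3-fold lower number from compound 2 to compound 3 (0.36 log units; beyond the scatter), and compound 1 lies further off. Compound 4 `Cc1ccc(C(=O)Nc2nnc(-c3cccc(O)c3O)s2)cc1` has not yet been measured. It arises from compound 2 by one change: 4-methylphenyl in place of phenoxymethyl on a carbonyl carbon. For the measured compounds named here, the only measured step touching the carbonyl carbon is a 1.1-fold higher number from compound 1 to compound 3 (0.04 log units; within the scatter), an exchange of 4-chlorophenyl for phenoxymethyl that left the number within the scatter. The exchange of phenoxymethyl for 4-methylphenyl is of the same kind, so no step beyond the scatter is expected in this assay, and the expected step is a 1.2-fold lower number from compound 2 to compound 4 (0.07 log units; within the scatter). Compound 4 is accordingly estimated at 100000 nM, within a range from 40000 nM to 250000 nM.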

Compound 4, half-maximal inhibitory concentration: 13400 nM
Compound 4: middle estimate off by 7.5-fold (0.87 log units), on the high side; the measured number lies below the stated range.
By their numbers in this assay, from the lowest: compound 4; then compounds 1 and 3 (each within the scatter of the next); then compound 2.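

The group on the carbonyl carbon can move the number well beyond the scatter: in this assay, 4-methylphenyl in place of phenoxymethyl gives an 8.7-fold lower number from compound 2 to compound 4 (0.94 log units; beyond the scatter). The earlier exchange at this carbon, on the 3,4-dihydroxyphenyl compounds, gave only a 1.1-fold higher number from compound 1 to compound 3 (0.04 log units; within the scatter), so the position is not silent, at least with the 2,3-dihydroxyphenyl group in place. No evidence here accounts for the size of this step.

The compounds shown leave open whether 4-methylphenyl would give a similar step with the 3,4-dihydroxyphenyl group. They also leave open what an amine or a carboxylic acid on the carbonyl-bound group would do.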